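Methyl on the fused ring: a small change from compound 3

The source may report more compounds than this note shows. Statements on the series, on what has been measured and on what is new or still open speak of the compounds shown alone.

Measured compounds:
compound 1, `O=C1N=C(N2N=C(c3ccccc3)CC2c2ccccc2O)S/C1=C1/C(=O)Nc2ccccc21`, 2030 nM
compound 2, `COc1ccc(C2CC(c3ccccc3)=NN2C2=NC(=O)/C(=C3\C(=O)Nc4ccccc43)S2)cc1`, 2380 nM
compound 3, `O=C1N=C(N2N=C(c3ccccc3)CC2c2ccc(Cl)cc2)S/C1=C1/C(=O)Nc2ccccc21`, 230 nM

In a functional assay on cells (Cancer cell lines, Homo sapiens) for cytotoxicity, read by sulforhodamine B assay, with a stated time of 48 h (on this read-out higher numbers stand for weaker inhibition of growth and lower numbers for stronger inhibition of growth), compound 3 gives the lowest number of the three, and its steps to the other two compounds are both beyond the scatter, so it is the most potent of the set: an 8.8-fold lower number from compound 1 to compound 3 (0.95 log units; beyond the scatter) and a 10-fold lower number from compound 2 to compound 3 (1.01 log units; beyond the scatter). Compound 4, `Cc1ccc2c(c1)/C(=C1\SC(N3N=C(c4ccccc4)CC3c3ccc(Cl)cc3)=NC1=O)C(=O)N2`, differs from compound 3 by methyl in place of hydrogen on an aromatic carbon. For the measured compounds named here, none of the measured steps touches this part of the shared core; the steps of a 1.2-fold higher number from compound 1 to compound 2 (0.07 log units; within the scatter), an 8.8-fold lower number from compound 1 to compound 3 (0.95 log units; beyond the scatter) and a 10-fold lower number from compound 2 to compound 3 (1.01 log units; beyond the scatter) all concern the ring on the saturated carbon. No step beyond the scatter is therefore expected in this assay. Compound 4 is estimated at 250 nM, between 80 nM and 800 nM, which would mean a 1.1-fold higher number from compound 3 to compound 4 (0.04 log units; within the scatter).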

Compound 4, concentration for 50% growth inhibition: 210 nM
For compound 4 the middle estimate is 1.2-fold (0.08 log units) above the measured one; the measured number falls inside the stated range.
By their numbers in this assay, from the lowest: compounds 4 and 3 (each within the scatter of the next); then compounds 1 and 2 (each within the scatter of the next).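

This is the first change shown on the fused part of the shared core, away from the ring on the saturated carbon, and in this assay the methyl in place of hydrogen gives a 1.1-fold lower number from compound 3 to compound 4 (0.04 log units; within the scatter) and leaves the two numbers within the scatter. At this aromatic carbon one added carbon atom therefore goes with no measurable difference, whereas the swap on the other ring gave a 10-fold lower number from compound 2 to compound 3 (1.01 log units; beyond the scatter) in the same test. Nothing measured here explains this tolerance.

As far as these compounds go, whether a longer chain such as propyl, an amine or a carboxylic acid would be accepted at this carbon remains open. So does the effect of a methyl on the other carbons of this six-membered ring.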